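The compounds below may be only part of what the source reports. "The series", "measured", "known", "first", "only" and "open" are said of these compounds alone.

Within the data shown here, compound 1 `O=C1Nc2ccc(C(c3ccccc3)c3ccccc3)cc2/C1=C/c1cccc(OCc2cn(Cc3ccccc3)nn2)c1` is one of the two measured members. In a functional assay on A549 cells (Homo sapiens) for inhibition, read by MTT assay, with a stated time of 48 h (a higher number here means a weaker inhibitor, a lower number a stronger inhibitor), compound 1 gives 14700 nM. Compound 2 `Cc1ccc(C(C#Cc2ccccc2)c2ccc3c(c2)/C(=C/c2cccc(OCc4cn(Cc5ccccc5)nn4)c2)C(=O)N3)cc1` is the other measured member. Compound 2 sits at a limit of this assay, > 50000 nM, so no number is known for it. Among the two values shown, one sits at that limit (the limit of > 50000 nM in this assay, at which 1 of the 2 values shown sits). Compound 3 `Cc1ccc(C(C#Cc2ccccc2)c2ccc3c(c2)/C(=C\c2cccc(OCc4cn(Cc5ccccc5)nn4)c2)C(=O)N3)cc1` differs from compound 2 in one place: the two compounds have the same atoms and bonds; at least one stereo element is drawn with a configuration in one of them and without one in the other: 1 of 2 stereo elements differ; a double bond is drawn Z in compound 2 and E in compound 3. Among the measured compounds shown here, no measured pair shows what this change does, and since compound 2 stands at a limit, any step in this assay can only be read from that limit toward a number or as none at all. The expected step from compound 2 to compound 3 in this assay is an at least 1.6-fold lower number from compound 2 to compound 3 (0.22 log units; that floor lies within the scatter), a guess that compound 3 reaches a measurable value, though a second limit remains quite possible. Compound 3 is therefore estimated at 30000 nM in this assay, with an expected range from 8000 nM to 100000 nM.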

Compound 3, half-maximal inhibitory concentration: 36600 nM
Compound 3: middle estimate off by 1.2-fold (0.09 log units), on the low side; low and high end bracket the measured number.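

In this assay, among these compounds, the change of the double bond from Z in compound 2 to E in compound 3 is the first change that can be read, and it amounts to an at least 1.3-fold lower number from compound 2 to compound 3 (0.13 log units; that floor lies within the scatter). Compound 2 has a limit, > 50000 nM, and not a number. From the compounds shown here alone, the step is therefore only a floor and its true size remains unknown because of that limit: the limit of > 50000 nM in this assay, at which 1 of the 3 values shown sits.

The compounds shown leave open what the same change of the double bond does in compound 1, and whether an amine or a carboxylic acid added to compound 3 would shift its value. It also remains uncertain how far the step reflects the Z and E forms alone, because of how the two compounds are drawn: the fact that one of compounds 2 and 3 is drawn with a defined configuration and the other without, at the place where they differ.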